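Ring-bound carbamoyl replaces a hydroxyethyl chain in a DPP-4 series

A few compounds are considered here, and "the series" means these few. Any claim that something is new, unique, unknown or untested is made for them only; others in the source may bear on it.

Two pyrrolidine-based compounds of the shared core have been measured. Compound 1 `CN(C)C(=O)C[C@@H]1CN[C@H](C(=O)N2CCC[C@H]2C#N)C1` gives 66% in an assay on the whole organism (plasma, strain Sprague-Dawley) for inhibition of Dipeptidyl peptidase 4 (Rattus norvegicus), with a stated time of 6 h, at a dose of 1 mg/kg by the oral route (on this read-out lower numbers stand for less inhibition and higher numbers for more inhibition at the one dose given (going by the name of the read-out)), and compound 2 `N#C[C@@H]1CCCN1C(=O)[C@@H]1C[C@H](CCO)CN1` gives 64% in this assay. The single step between them, a number 2 percentage points lower from compound 1 to compound 2 (within the scatter), lies within the scatter, so the two values cannot be ordered and compound 2 stands level with compound 1 on the numbers shown.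

Compound 3 `CCN(C)C(=O)[C@@H]1CN[C@H](C(=O)N2CCC[C@H]2C#N)C1` has not yet been measured. It differs from compound 2 by ethyl(methyl)carbamoyl in place of 2-hydroxyethyl on a saturated ring carbon. Within the data shown here, no measured step moves a group onto the ring carbon itself, and the only step known, from compound 1 to compound 2, exchanges groups on a chain carbon and stays within the scatter. That step shows that a carbamoyl group and a hydroxy-bearing chain in this region gave much the same inhibition, which points to no change beyond the scatter here either. Compound 3 is therefore expected to show an estimated step of a number 1 percentage points lower from compound 2 to compound 3 (within the scatter). The estimate for compound 3 in this assay is 63%, with a range from 45% to 78%.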

Compound 3, a percentage reported as inhibition, in the whole organism at one dose (the size of the read-out at that dose, not a potency): 71%
Compound 3: the middle estimate sits 8 percentage points below what was measured, within the range that was stated.
By their numbers in this assay, from the lowest: compounds 2, 1 and 3 (each within the scatter of the next).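

In this assay, the ring carbon two ring bonds from the ring nitrogen now carries a carbamoyl group directly, rather than through a chain, and the exchange of 2-hydroxyethyl for ethyl(methyl)carbamoyl gives a number 7 percentage points higher from compound 2 to compound 3 (within the scatter) even though the entering group has 6 heavy atoms against 3 and 0 hydrogen-bond donors against 1. Moving from (dimethylcarbamoyl)methyl to ethyl(methyl)carbamoyl at the same carbon gives a number 5 percentage points higher from compound 1 to compound 3 (within the scatter) and so adds a second exchange at this position that leaves the read-out inside the scatter, which the single earlier step could not show. Nothing shown explains why these different groups give indistinguishable numbers at this dose.

As far as these compounds go, all three groups at this carbon are uncharged, so it remains open whether a primary amine, a carboxylic acid or a longer chain ending in a phenyl ring would move the read-out beyond the scatter. With one dose and one time point, the numbers also leave open whether differences between these compounds would appear at a lower dose or a later time.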